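Amino to methoxy on a triazole-linked aryl pair

The source may report more compounds than this note shows. Statements on the series, on what has been measured and on what is new or still open speak of the compounds shown alone.

Compound 1, `COc1ccc(-n2cc(-c3ccc(OC)c(OC)c3)nn2)c(OC)c1`, in a functional assay on MDA-MB-231 cells (Homo sapiens) for cytotoxicity, read by MTT assay; on this read-out higher numbers stand for weaker inhibition and lower numbers for stronger inhibition: "not determined" (no result reported)
Compound 2, `COc1ccc(-c2cn(-c3ccc(OC)cc3)nn2)cc1`: > 100 nM
Compound 3, `COc1ccc(-n2cc(-c3ccc(N)cc3)nn2)c(OC)c1`: > 10000 nM

Compound 3 carries an amino group on one aryl ring and two methoxy groups on the other. In this assay compound 3 gives only a limit, > 10000 nM, and no number. Compound 2 likewise gives only a limit, > 100 nM. Compound 1 has no result in this assay, "not determined" (no result reported). Compound 3 thus stands at the weaker of the two limits shown, (the limit of > 10000 nM in this assay, at which 1 of the 3 values shown sits), while the other limit is the limit of > 100 nM in this assay, at which 1 of the 3 values shown sits.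

Compound 4, `COc1ccc(-c2cn(-c3ccc(OC)cc3OC)nn2)cc1`, differs from compound 3 by methoxy in place of amino on an aromatic carbon. Among the measured compounds shown here, no step between measured compounds is available, so the size of this change in this assay can only be guessed. The account expects the step from compound 3 to compound 4 to run toward stronger inhibition by an at least 3.3-fold lower number from compound 3 to compound 4 (0.52 log units; beyond the scatter), since methoxy-bearing compound 2 sits at the tighter limit > 100 nM. For compound 4 the estimate is 3000 nM, within 300 nM to 30000 nM.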

Compound 4, half-maximal inhibitory concentration: > 10000 nM
Compound 4: only a limit was reported (the forecaster's own chance of this, stated with the estimate: 50%); at least 3.3-fold (0.52 log units) between middle value and limit.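

In this assay compound 4 gives only a limit, > 10000 nM, so the steps to it from compound 3 and from compound 2 cannot be read. The compounds shown leave open what size of change, if any, methoxy in place of amino brings in this assay.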